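Amide variation at the carbonyl of the shared core

A few compounds are considered here, and "the series" means these few. Any claim that something is new, unique, unknown or untested is made for them only; others in the source may bear on it.

Measured compounds and values in a functional assay for inhibition of nuclear factor NF-kappa-B complex (Homo sapiens); on this read-out lower numbers stand for stronger inhibition and higher numbers for weaker inhibition:
compound 1 `COc1ccc2c(c1)OC(c1cc(OC)c(OC)c(OC)c1)C(C(=O)OC(C)C)=C2`: 11800 nM
compound 2 `COc1ccc2c(c1)OC(c1cc(OC)c(OC)c(OC)c1)C(C(=O)N1CCCCC1)=C2`: > 50000 nM

For compound 2 the value is a limit of this assay, not a number; it sits at the limit of > 50000 nM in this assay, at which 1 of the 2 values shown sits. Among the compounds with values here, compound 1 is the only member of the pair with a measured number, and the step of an at least 4.2-fold higher number from compound 1 to compound 2 (0.62 log units; beyond the scatter) is the one step that bears on the carbonyl substituent.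

Compound 3 `COc1ccc2c(c1)OC(c1cc(OC)c(OC)c(OC)c1)C(C(=O)N(C)OC)=C2` carries the change (methoxy(methyl)amino in place of piperidin-1-yl on a carbonyl carbon). Within the data shown here, the only measured step at this position moved away from the isopropoxy ester and weakened inhibition past the limit; no measured step tells how one amine on the carbonyl compares with another. Compound 3 is therefore expected to stay weak, with the step of an at least 1.2-fold lower number from compound 2 to compound 3 (0.09 log units; that floor lies within the scatter) estimated to fall within the scatter and a real chance that it, too, would end up at a limit of this assay rather than at a number. The estimate for compound 3 in this assay is 40000 nM, with a range from 10000 nM to 160000 nM.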

Compound 3, half-maximal inhibitory concentration: 11700 nM
The estimate for compound 3 lay 3.4-fold (0.53 log units) above the measured number; measured number inside the range.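

In this assay, the nitrogen group on this carbonyl makes a difference: methoxy(methyl)amino in place of piperidin-1-yl gives an at least 4.2-fold lower number from compound 2 to compound 3 (0.63 log units; beyond the scatter). For compound 2 the value is a limit in this assay, and the size of this step is known only as a floor: the limit of > 50000 nM in this assay, at which 1 of the 3 values shown sits. Methoxy(methyl)amino in place of isopropoxy gives a 1.0-fold lower number from compound 1 to compound 3 (0.00 log units; within the scatter), so the loss seen with piperidin-1-yl does not extend to every nitrogen group on this carbonyl.

The change removes a ring and brings in an oxygen at once, and the compounds shown do not separate these two features; dimethylamino or morpholin-4-yl on the carbonyl would bear on that. As far as these compounds go, it also remains open whether any group here, such as a free carboxylic acid or a secondary amide, gives stronger inhibition than compound 1 and compound 3.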